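Fluoro for Ethoxy on a Shared Core

The source may hold more compounds than are shown below. What is called first, only, known or untested is meant among the compounds shown, and "the series" means these compounds.

The series shares one core, seen in compound 1 `CCOc1ccc2nc(Cl)c(/C=C3\SC(=S)NC3=O)cc2c1`. In a toxicity assay on PANC-1 cells (Homo sapiens) for cytotoxicity, read by MTT assay, with a stated time of 48 h (on this read-out lower numbers stand for stronger inhibition of growth and higher numbers for weaker inhibition of growth), compound 1 gives > 100 ug/mL, which is a limit of the assay and not a number. Compound 2 `Cc1cccc2cc(/C=C3\SC(=S)N(CC(=O)O)C3=O)c(Cl)nc12` is a second member. In this assay compound 2 gives > 100 ug/mL, again a limit rather than a measured figure. Compound 3 `COc1ccc2cc(/C=C3\SC(=S)NC3=O)c(Cl)nc2c1` completes the measured set. In this assay compound 3 gives > 100 ug/mL, likewise a limit. Among the compounds with values here, compound 1 thus stands nowhere distinct: every measured value rests at the limit of > 100 ug/mL in this assay, at which 3 of the 3 values shown sit, and no step between measured compounds can be drawn.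

Compound 4 `O=C1NC(=S)S/C1=C\c1cc2cc(F)ccc2nc1Cl` has not been measured. It differs from compound 1 by fluoro in place of ethoxy on an aromatic carbon. Because all three measured compounds sit at the limit of > 100 ug/mL in this assay, at which 3 of the 3 values shown sit, no direction for this change can be read from the data. Compound 4 is therefore expected to show no step beyond the scatter, and the estimated step of a number no higher from compound 1 to compound 4 (the limit leaves the size open) reflects that. For compound 4 the expected value is 100 ug/mL, with a range from 40 ug/mL to 250 ug/mL, and most likely this assay would again report only a limit.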

Compound 4, concentration for 50% growth inhibition: > 100 ug/mL
Compound 4 ended at the assay's limit; the forecaster's own chance of this, stated with the estimate: 80%; the middle value lies on the limit itself.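

No new step can be read between compound 1 and compound 4, because both rest at a limit of the assay rather than at a number: the limit of > 100 ug/mL in this assay, at which 4 of the 4 values shown sit.

The compounds shown leave open whether fluoro in place of ethoxy alters growth inhibition at all.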